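The source may report more compounds than this note shows. Statements on the series, on what has been measured and on what is new or still open speak of the compounds shown alone.

Three amides of the shared core have been tested in an assay on brain for inhibition of Gastrin/cholecystokinin type B receptor (Rattus norvegicus); on this read-out lower numbers stand for stronger inhibition and higher numbers for weaker inhibition. Compound 1 `CCCCCCCCCCNC(=O)Cc1c(-c2ccccc2)[nH]c2ccccc12` carries a decyl chain; in this assay compound 1 gives only a limit, > 1000 nM. Compound 2 `CCCCCCCCCCCCCCCCCCNC(=O)Cc1c(-c2ccccc2)[nH]c2ccccc12` carries an octadecyl chain; in this assay compound 2 likewise gives only a limit, > 1000 nM. Compound 3 `CCCCCCNC(=O)Cc1c(-c2ccccc2)[nH]c2ccccc12` carries a hexyl chain; in this assay compound 3 also gives only a limit, > 1000 nM. Compound 3 therefore stands at the limit of > 1000 nM in this assay, at which 3 of the 3 values shown sit, and no ordering among the three can be read. The steps between them are correspondingly unreadable: a step that the two limits leave unreadable from compound 1 to compound 3 and a step that the two limits leave unreadable from compound 2 to compound 3, as is a step that the two limits leave unreadable from compound 1 to compound 2.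

Compound 4 `CCCCCCNC(=O)Cc1c(-c2ccc(F)cc2)[nH]c2ccccc12` differs from compound 3 by fluoro in place of hydrogen on an aromatic carbon, cut one bond further out, phenyl to 4-fluorophenyl. Among the compounds with values here, none of the measured steps touches this ring, so none bears on it directly; the three limits are the only guide. The author expects compound 4 to sit close to compound 3, a step that the limit leaves unreadable from compound 3 to compound 4, and estimates for compound 4 a value of 3000 nM, within 800 nM to 15000 nM, most probably again reported only as a limit.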

Compound 4, half-maximal inhibitory concentration: > 1000 nM
Compound 4: no number, only a limit; the forecaster's own chance of this, stated with the estimate: 80%; the middle value lies beyond the limit too.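

In this assay, within the data shown here, compound 4, like compound 3, gives only a limit, so the step between these two compounds cannot be read and no new step follows. The compounds shown leave open whether chain length or the fluoro group changes inhibition at all, because every value is a limit: the limit of > 1000 nM in this assay, at which 4 of the 4 values shown sit.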